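The source may report more compounds than this note shows. Statements on the series, on what has been measured and on what is new or still open speak of the compounds shown alone.

Measured so far in a functional assay on HCT-116 cells (Homo sapiens) for inhibition; a lower number here means a stronger inhibitor, a higher number a weaker inhibitor:
compound 1 `Oc1ccc(/C=C/c2ccc3ccccc3c2)cc1` gives 4060 nM
compound 2 `COc1ccc(/C=C/c2ccc3ccccc3c2)cc1` gives > 5000 nM, a limit of the assay rather than a number

Where compound 2 stands: in this assay compound 2 reaches only the limit > 5000 nM, so its potency is known as a bound and not as a value. the limit of > 5000 nM in this assay, at which 1 of the 2 values shown sits, is that bound, and compound 2 is the one sitting at it. Among the measured compounds shown here, the single measured step, an at least 1.2-fold higher number from compound 1 to compound 2 (0.09 log units; that floor lies within the scatter), shows methyl in place of hydrogen on the oxygen giving nothing beyond the scatter, with the true size of that step open on the upper side.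

Compound 3 `FC(F)(F)c1ccc(/C=C/c2ccc3ccccc3c2)cc1` carries trifluoromethyl in place of methoxy on an aromatic carbon, that is, trifluoromethyl in place of methoxy on an aromatic carbon. For the measured compounds named here, the step from compound 1 to compound 2 bears on it only in showing that a change at this aromatic carbon from hydrogen to methyl on the oxygen brought no gain; no measured step covers a trifluoromethyl here. The expected step is therefore a step that the limit leaves unreadable from compound 2 to compound 3, of no clear direction beyond the scatter and starting from a limit. Compound 3 is estimated at 8000 nM, within 3000 nM to 30000 nM, with a fair chance that only a limit is again reported.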

Compound 3, half-maximal inhibitory concentration: > 5000 nM
Compound 3: a limit, no number (the forecaster's own chance of this, stated with the estimate: 65%); the middle value is on the limit's open side.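

In this assay compound 3 is reported only as a limit, > 5000 nM, so a second, quite different group on this aromatic carbon, para to a large group, also yields no number. Trifluoromethyl in place of hydroxy gives an at least 1.2-fold higher number from compound 1 to compound 3 (0.09 log units; that floor lies within the scatter), so this change, like methyl on the oxygen, shows no lower number than the hydroxy of compound 1, while the true size of the step stays open on the upper side. The change from methoxy to trifluoromethyl cannot be read, because compound 2 and compound 3 sit at the same limit: the limit of > 5000 nM in this assay, at which 2 of the 3 values shown sit.

Among the compounds shown here, compound 1 remains the only compound of the three with a measured number, so how far compound 2 and compound 3 lie from it, and whether they differ from each other, stays open. Also open is whether any group on this carbon gives a lower number than the hydroxy does, with an amine or a carboxylic acid on the same carbon as replacements that the compounds shown do not cover.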